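Swapping the aryl group on a pyrazolone hydrazide

This account rests on a few compounds, and the source may have more. Where it says the series, first, only, none or still open, it means among the compounds named here.

Measured so far:
- compound 1 `O=C(CO[N+](=O)[O-])NNC(=O)c1ccc(-n2[nH]c(=O)cc2-c2ccc([N+](=O)[O-])cc2)cc1` gives 23.6% in a functional assay on the whole organism (strain Wistar) for inhibition, with Rattus norvegicus as the target, read by paw edema, with a stated time of 1 h, at a dose of 6 mg/kg by the oral route; on this read-out higher numbers stand for more inhibition at the one dose given (going by the name of the read-out) and lower numbers for less inhibition
- compound 2 `COc1ccccc1-c1cc(=O)[nH]n1-c1ccc(C(=O)NNC(=O)CO[N+](=O)[O-])cc1` gives 55.1% in this assay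
- compound 3 `O=C(CO[N+](=O)[O-])NNC(=O)c1ccc(-n2[nH]c(=O)cc2-c2ccccc2O)cc1` gives 23% in this assay

Compound 3 has the lowest number of the three in this assay, though its gap to compound 1 lies within the scatter; only compound 2 stands clearly apart, and that step was a number 32.1 percentage points lower from compound 2 to compound 3 (beyond the scatter). The next compound, compound 4 `O=C(CO[N+](=O)[O-])NNC(=O)c1ccc(-n2[nH]c(=O)cc2-c2ccc(Cl)cc2)cc1`, is not yet measured. It differs from compound 3 in one place: 4-chlorophenyl in place of 2-hydroxyphenyl on an aromatic carbon.

Within the data shown here, two measured steps bear on this change. Putting 2-hydroxyphenyl in place of 4-nitrophenyl gave a number 0.6 percentage points lower from compound 1 to compound 3 (within the scatter), so a group at that position carrying a 4-substituent and one carrying a 2-hydroxyl gave much the same read-out. Only 2-methoxyphenyl, in a number 31.5 percentage points higher from compound 1 to compound 2 (beyond the scatter), stood out. Compound 4 carries 4-chlorophenyl, which resembles the 4-nitrophenyl of compound 1 more than the 2-methoxyphenyl of compound 2. For compound 4 the expected step is therefore a number 4 percentage points higher from compound 3 to compound 4 (within the scatter), none beyond the scatter. Compound 4 is estimated at 27%, within a range of 14% to 44%.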

Compound 4, a percentage reported as inhibition, in the whole organism at one dose (the size of the read-out at that dose, not a potency): 5.88%
The estimate for compound 4 lay 21.1 percentage points above the measured number; the measured number lies below the stated range.
By their numbers in this assay, from the lowest: compound 4; then compounds 3 and 1 (each within the scatter of the next); then compound 2.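

Chloro in place of nitro gave a number 17.7 percentage points lower from compound 1 to compound 4 (beyond the scatter) in this assay, so sharing a 4-substituent on the phenyl ring does not make two groups read alike at this position. The 4-chlorophenyl group also gave lower numbers than the two groups with a substituent named at the 2-position, with a number 17.1 percentage points lower from compound 3 to compound 4 (beyond the scatter) and a number 49.2 percentage points lower from compound 2 to compound 4 (beyond the scatter) here. The close match of compound 1 and compound 3 therefore did not mark a floor for this position, though nothing shown gives a measured reason for these differences.

On these data alone, it remains open whether the high number of compound 2 comes from the methoxy group itself or from where it sits on the phenyl ring. As far as these compounds go, how an unsubstituted phenyl, or a phenyl carrying an amine or a carboxylic acid, would read here is also open.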